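Shortening the thioamide chain on two pyridazinone-type cores

The source may hold more compounds than are shown below. What is called first, only, known or untested is meant among the compounds shown, and "the series" means these compounds.

In a functional assay on the whole organism (stomach) with Rattus norvegicus as the target (on this read-out lower numbers stand for an effect already at smaller amounts and higher numbers for an effect only at larger amounts of compound), compound 1, with the structure `Cc1ccc(=O)n(CCCCCCC(=N)S)n1`, returns only a limit of the assay, > 100 mg/kg. Compound 2, `Cc1ccc(=O)n(CCCCC(=N)S)n1`, is likewise reported only as a limit, > 100 mg/kg. The change between these two is a group of 3 heavy atoms (1 carbon, 1 nitrogen, 1 sulfur; no ring) in place of a group of 5 heavy atoms (3 carbon, 1 nitrogen, 1 sulfur; no ring), on a saturated chain carbon, four bonds along the chain from an aromatic nitrogen, and its step in this assay is a step that the two limits leave unreadable from compound 1 to compound 2. Among the measured compounds shown here, compound 3, `N=C(S)CCCCN1N=C(c2ccccc2)CCC1=O`, carries the only plain number of the set, giving 100 mg/kg in this assay. The difference between the core of compound 3 and the core of compound 1 is not broken down here. Compound 4, `N=C(S)CCN1N=C(c2ccccc2)CCC1=O`, has not yet been measured; it differs from compound 3 by a group of 3 heavy atoms (1 carbon, 1 nitrogen, 1 sulfur; no ring) in place of a group of 5 heavy atoms (3 carbon, 1 nitrogen, 1 sulfur; no ring), on a saturated chain carbon, two bonds along the chain from an amide-type nitrogen in a ring. This is the same kind of change as that from compound 1 to compound 2, though the place differs: there the group sat four bonds along the chain from an aromatic nitrogen, here two bonds along the chain from an amide-type nitrogen in a ring. Because (the limit of > 100 mg/kg in this assay, at which 2 of the 3 values shown sit), the earlier step gives no readable size, so the expected step from compound 3 to compound 4 is estimated as a 1.5-fold higher number from compound 3 to compound 4 (0.18 log units; within the scatter), and compound 4 is expected to give about 150 mg/kg in this assay, between 60 mg/kg and 400 mg/kg.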

Compound 4, dose for half-maximal effect: > 100 mg/kg
Compound 4: a limit, no number; the forecaster's own chance of this, stated with the estimate: 55%; the middle value lies beyond the limit too.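

Shortening the chain on the core of compound 3 gives, in this assay, a number no lower from compound 3 to compound 4 (the limit leaves the size open). Among the compounds shown here, this shows only that the change does not bring the number down on this core; on the core of compound 1, the same kind of change links two limits and gives no direction at all. Neither step has a readable size, so it remains unknown whether the change acts to the same extent on the two cores, because the results mostly stop at a single limit: the limit of > 100 mg/kg in this assay, at which 3 of the 4 values shown sit.

On these data alone, whether a longer chain on the core of compound 3, or an amine or a carboxylic acid at the chain end in place of the thioamide, would give a plain number that differs from that of compound 3 (100 mg/kg) stays open. Also open, as far as these compounds go, is how the same shortening would behave on any core other than these two.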